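A few compounds are considered here, and "the series" means these few. Any claim that something is new, unique, unknown or untested is made for them only; others in the source may bear on it.

Half-life values in an ADME assay on microsomes from liver (Homo sapiens) for metabolic stability; a lower number here means that the compound disappears faster, a higher number that the compound lasts longer:

- Compound 1 `CC(C)C(/C=C1\NC(=O)NC1=O)c1ccc(-c2ccc3cccc(F)c3c2)[nH]c1=O`: > 3 h, a limit
- Compound 2 `C/C(=C1/OC(=O)NC1=O)C(c1ccc(-c2ccc3cccc(F)c3c2)[nH]c1=O)C(C)C`: > 3 h, a limit
- Compound 3 `CC(C)C(/C=C1\SC(=O)NC1=O)c1ccc(-c2ccc3cccc(F)c3c2)[nH]c1=O`: > 3 h, a limit

The three measured compounds share one reading: the limit of > 3 h in this assay, at which 3 of the 3 values shown sit. Compound 3 stands at > 3 h, which is a limit of the assay and not a number.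

Compound 4 `CC(C)C(CC1NC(=O)NC1=O)c1ccc(-c2ccc3cccc(F)c3c2)[nH]c1=O` is not yet measured. It differs from compound 3 by a group of 8 heavy atoms (4 carbon, 2 nitrogen, 2 oxygen; one five-membered non-aromatic ring with 2 hetero atoms) in place of a group of 8 heavy atoms (4 carbon, 1 nitrogen, 2 oxygen, 1 sulfur; one five-membered non-aromatic ring with 2 hetero atoms), on a saturated chain carbon bound to an aromatic carbon and a saturated chain carbon, with the (2,5-dioxoimidazolidin-4-yl)methyl group entering on a saturated chain carbon bound to an aromatic carbon and a saturated chain carbon.

Three measured exchanges at this same place bear on the change: a step that the two limits leave unreadable from compound 1 to compound 2, a step that the two limits leave unreadable from compound 1 to compound 3 and a step that the two limits leave unreadable from compound 2 to compound 3. Each joins two limits, so none gives a size. No shift beyond the usual scatter is therefore expected in this assay, and no direction can be named. The expected step is a number no higher from compound 3 to compound 4 (the limit leaves the size open). Another limit would be no surprise. Compound 4 is estimated at 3 h, with an expected range from 1.5 h to 6 h.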

Compound 4, half-life: 1.59 h
For compound 4 the middle estimate is 1.9-fold (0.28 log units) above the measured one; the measured number falls inside the stated range.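

Among these compounds, with an at least 1.8-fold lower number from compound 3 to compound 4 (0.27 log units; that floor lies within the scatter) and an at least 1.8-fold lower number from compound 2 to compound 4 (0.27 log units; that floor lies within the scatter) and an at least 1.8-fold lower number from compound 1 to compound 4 (0.27 log units; that floor lies within the scatter) the (2,5-dioxoimidazolidin-4-yl)methyl group of compound 4 gives the first reading at this place in this assay that is a number and not a limit, though each floor lies within the usual scatter. Among the compounds shown here, the steps among the earlier compounds cannot be read, and their three groups on a saturated chain carbon bound to an aromatic carbon and a saturated chain carbon share a single limit of the assay: the limit of > 3 h in this assay, at which 3 of the 4 values shown sit.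

The compounds shown leave open the full size of these steps and whether the three compounds at the limit differ among themselves. They also leave open how this assay would read with an amine or a carboxylic acid in place of this group at the same place.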